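The source may hold more compounds than are shown below. What is called first, only, known or untested is meant among the compounds shown, and "the series" means these compounds.

Compound 1, `COc1ccc(-c2cn(C[C@H]3COC(C)(C)O3)nn2)cc1`, was tested in a functional assay on B16 cells (Mus musculus) for cytotoxicity, read by MTT assay, with a stated time of 48 h; on this read-out higher numbers stand for weaker inhibition and lower numbers for stronger inhibition. In this assay compound 1 gives > 100000 nM, which is a limit of the assay rather than a number. Compound 2, `CC1(C)OC[C@H](Cn2cc(-c3ccc([N+](=O)[O-])cc3)nn2)O1`, differs from compound 1 only by a nitro in place of a methoxy on an aromatic carbon. In this assay compound 2 gives > 100000 nM, again a limit of the assay. The step between them, a step that the two limits leave unreadable from compound 1 to compound 2, cannot be read in size or direction because both values sit at the limit of > 100000 nM in this assay, at which 2 of the 2 values shown sit. Compound 3, `COc1ccc(-c2cn(CCCO)nn2)cc1`, has not yet been measured; it differs from compound 1 by 2-hydroxyethyl in place of 2,2-dimethyl-1,3-dioxolan-4-yl on a saturated chain carbon bound to an aromatic nitrogen. Going by the values given here, no measured step touches this kind of change, so the only guide is that compound 1 reaches no number at all in this assay. With nothing to suggest a shift, compound 3 is expected to behave much like compound 1, a step of about a number no higher from compound 1 to compound 3 (the limit leaves the size open), and most likely to give again only a limit. The estimate for compound 3 in this assay is 100000 nM, with a range from 30000 nM to 300000 nM.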

Compound 3, half-maximal inhibitory concentration: > 100000 nM
Compound 3: no number, only a limit; the forecaster's own chance of this, stated with the estimate: 85%; the middle value lies on the limit itself.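

Compound 3, like compound 1, gives only a limit of the assay and not a number in this assay, so no step can be read between them: the limit of > 100000 nM in this assay, at which 3 of the 3 values shown sit.

The compounds shown leave open whether 2-hydroxyethyl in place of 2,2-dimethyl-1,3-dioxolan-4-yl changes anything in this assay, and what number, if any, each compound would reach.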